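A few compounds are considered here, and "the series" means these few. Any claim that something is new, unique, unknown or untested is made for them only; others in the source may bear on it.

Measured compounds:
- compound 1, `CC1(C)O[C@@H](CO)[C@H](Cn2cc(Cn3c4c(c5ccccc53)C(=O)c3c[n+]([O-])c5ccccc5c3C4=O)nn2)O1`: 370 nM
- compound 2, `CC1(C)OC[C@H](Cn2cc(Cn3c4c(c5ccccc53)C(=O)c3c[n+]([O-])c5ccccc5c3C4=O)nn2)O1`: 340 nM

In a functional assay on A549 cells (Homo sapiens) for cytotoxicity, read by MTT assay, with a stated time of 72 h (a lower number here means a stronger inhibitor, a higher number a weaker inhibitor), compound 2 gives 340 nM and compound 1 gives 370 nM; the two numbers sit within the scatter of each other, so neither compound can be put ahead of the other.

Compound 3, `O=C1c2c[n+]([O-])c3ccccc3c2C(=O)c2c1c1ccccc1n2Cc1cn(C[C@@H](O)CO)nn1`, is not yet measured. It differs from compound 2 by 1,2-dihydroxyethyl in place of 2,2-dimethyl-1,3-dioxolan-4-yl on a saturated chain carbon bound to an aromatic nitrogen.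

Within the data shown here, the only measured step, a 1.1-fold lower number from compound 1 to compound 2 (0.04 log units; within the scatter), concerns a different place on the shared core and a different kind of change, so it says nothing direct about opening the dioxolane to the diol; it shows only that a change on this side chain left the number in this assay unmoved. Among the measured compounds shown here, no step among the measured compounds tests the present change. The expectation for compound 3 is therefore a step of a 1.0-fold higher number from compound 2 to compound 3 (0.01 log units; within the scatter), not beyond the scatter, in either direction.

Compound 3 is estimated to give 350 nM in this assay, in the range 150 nM to 900 nM.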

Compound 3, half-maximal inhibitory concentration: 390 nM
Compound 3: the middle estimate sits 1.1-fold (0.05 log units) below what was measured; the range from low to high includes it.
By their numbers in this assay, from the lowest: compounds 2, 1 and 3 (each within the scatter of the next).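

In this assay the step of a 1.1-fold higher number from compound 2 to compound 3 (0.06 log units; within the scatter) replaces 2,2-dimethyl-1,3-dioxolan-4-yl with 1,2-dihydroxyethyl on a saturated chain carbon bound to an aromatic nitrogen, and it stays within the scatter even though the ring is gone and hydrogen-bond donors enter where the leaving group had none. The step of a 1.1-fold higher number from compound 1 to compound 3 (0.02 log units; within the scatter) also stays within the scatter, so in this assay the open-chain diol cannot be told apart from either dioxolane, whether or not that ring carries hydroxymethyl. Nothing available explains why these changes leave the number in place.

From the compounds shown here alone, whether an amine, a carboxylic acid or a longer chain at this place would move the number remains open. Also open, going by these compounds, is whether the 1,2-dihydroxyethyl group with its stereocentre inverted would read the same.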